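Swapping methoxy for chloro on a diacetylamino compound

The compounds below may be only part of what the source reports. "The series", "measured", "known", "first", "only" and "open" are said of these compounds alone.

compound 1 `COc1ccc(-c2c(-c3cc(OC)c(OC)c(OC)c3)noc2N)cc1` gives 5840 nM
compound 2 `COc1cc(-c2noc(NC(C)=O)c2-c2ccc(Cl)cc2)cc(OC)c1OC` gives 9530 nM
compound 3 `COc1ccc(-c2c(-c3cc(OC)c(OC)c(OC)c3)noc2N(C(C)=O)C(C)=O)cc1` gives 390 nM

All three values come from a functional assay on ECa-109 cells (Homo sapiens) for cytotoxicity, read by MTT assay, with a stated time of 48 h (on this read-out lower numbers stand for stronger inhibition and higher numbers for weaker inhibition), and compound 3 has the lowest number. Compound 4 `COc1cc(-c2noc(N(C(C)=O)C(C)=O)c2-c2ccc(Cl)cc2)cc(OC)c1OC` differs from it in one place: chloro in place of methoxy on an aromatic carbon. Going by the values given here, the one measured single change, a 15-fold lower number from compound 1 to compound 3 (1.18 log units; beyond the scatter), was large, but it concerns diacetylamino in place of amino, and compound 4 keeps the diacetylamino group. Among the compounds with values here, no measured step isolates the new swap. Compound 1 and compound 2 lie within the scatter of each other, but they differ in more than this swap. A small rise is expected, with a 1.8-fold higher number from compound 3 to compound 4 (0.25 log units; within the scatter) estimated in this assay, perhaps no larger than the scatter. Compound 4 is expected at 700 nM, within an estimated range of 150 nM to 3000 nM.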

Compound 4, half-maximal inhibitory concentration: 39800 nM
Compound 4: the middle estimate sits 57-fold (1.75 log units) below what was measured, and the stated range ends below it.
By their numbers in this assay, from the lowest: compound 3; then compounds 1 and 2 (each within the scatter of the next); then compound 4.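

In this assay, going by these compounds alone, the change from 4-methoxyphenyl to 4-chlorophenyl gives a 100-fold higher number from compound 3 to compound 4 (2.01 log units; beyond the scatter), so this position, para to a large group, matters far more than the earlier compounds could show. With chloro in place, acetyl on the amide-type nitrogen gives a 4.2-fold higher number from compound 2 to compound 4 (0.62 log units; beyond the scatter), so the diacetylamino group does not bring a lower number here. Nothing available explains either rise. As far as these compounds go, it remains open whether fluoro, methyl or hydroxy at this position would read closer to compound 3 or compound 4, and how an amino group would fare alongside chloro.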